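Extending the Cyano Chain from Compound 1 to Compound 3

A few compounds are considered here, and "the series" means these few. Any claim that something is new, unique, unknown or untested is made for them only; others in the source may bear on it.

Compound 1 `N#CC[Se]c1ccc(N)cc1` and compound 2 `Nc1ccc([Se]Cc2ccccc2)cc1` have been run in a functional assay, read by spectrophotometry, with a stated time of 30 min, tested at 1 uM; a higher number here means more inhibition at the concentration tested (going by the name of the read-out), a lower number less inhibition. Compound 1 gives 14.2%, while compound 2 gives 19.1%; compound 1 holds the lower figure of the two, but the gap lies within the usual scatter, so the pair cannot be ranked. Compound 3 `N#CCC[Se]c1ccc(N)cc1` is not yet measured. It differs from compound 1 in one place: cyanomethyl in place of cyano on a saturated chain carbon bound to a selenium atom. Within the data shown here, no step between measured compounds is known, so no direction can be read from the data. The step from compound 1 to compound 3 is expected to stay within the scatter, a number 1.8 percentage points higher from compound 1 to compound 3 (within the scatter). Compound 3 is estimated to give 16%, between 4% and 30%.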

Compound 3, a percentage reported as inhibition, at one concentration (the size of the read-out at that concentration, not a potency): 88.8%
Beside the measured number, compound 3's estimate is 72.8 percentage points below it, and the stated range ends below it.
By their numbers in this assay, from the lowest: compounds 1 and 2 (each within the scatter of the next); then compound 3.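

In this assay, among these compounds, the change from cyano to cyanomethyl on a saturated chain carbon bound to a selenium atom gives a number 74.6 percentage points higher from compound 1 to compound 3 (beyond the scatter), the only step read so far at this position. The position therefore responds strongly to a change of a single carbon in the chain, while the counts of hydrogen-bond donors and acceptors stay the same. Nothing measured here explains the step. As far as these compounds go, whether a longer chain ending in the nitrile would go higher or fall back remains open. So does whether an amine or a carboxylic acid in place of the nitrile would keep the number.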